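A few compounds are considered here, and "the series" means these few. Any claim that something is new, unique, unknown or untested is made for them only; others in the source may bear on it.

Three compounds have been measured in a functional assay on HepG2 cells (Homo sapiens) for cytotoxicity; a higher number here means a weaker inhibitor, a lower number a stronger inhibitor:

Compound 1 `Cc1ccc(S(=O)(=O)N/C(=N\O)Nc2ccc(Cl)cc2)cc1`: 49 ug/mL
Compound 2 `O=[N+]([O-])c1ccc(Oc2c(Cl)cc(S(=O)(=O)N/C(=N\O)Nc3ccc(Cl)cc3)cc2Cl)cc1`: 22 ug/mL
Compound 3 `O=[N+]([O-])c1ccc(Oc2c(Cl)cc(S(=O)(=O)N/C(=N\O)Nc3ccc(Cl)cc3)cc2Cl)c(Cl)c1`: 49 ug/mL

Compound 2 and compound 3 share a core and differ by chloro in place of hydrogen on an aromatic carbon, a change that gave a 2.2-fold higher number from compound 2 to compound 3 (0.35 log units; beyond the scatter). Compound 1 has a different core, and the difference between the two cores is not broken down here; compound 1 and compound 3 stand level in this assay, while compound 2 gives the lowest of the three numbers.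

Compound 4 `Cc1ccc(S(=O)(=O)N/C(=N\O)Nc2ccc(Cl)c(Cl)c2)cc1` is not yet measured. It differs from compound 1 by chloro in place of hydrogen on an aromatic carbon. Within the data shown here, this is the same kind of change as the one from compound 2 to compound 3, but not the same: there the chloro entered ortho to a large group and meta to a nitro group, here it enters ortho to a chloro group and meta to a large group, and on the other core.

Among the measured compounds shown here, with only one measured example of this kind of change, the expectation rests on it: a step of a 1.4-fold higher number from compound 1 to compound 4 (0.15 log units; within the scatter) is expected from compound 1 to compound 4, modest like the earlier one, because of a 2.2-fold higher number from compound 2 to compound 3 (0.35 log units; beyond the scatter). Compound 4 is therefore estimated at 70 ug/mL, with a likely range from 30 ug/mL to 150 ug/mL.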

Compound 4, half-maximal inhibitory concentration: 72 ug/mL
The estimate for compound 4 lay 1.0-fold (0.01 log units) below the measured number, and the stated range covers the measured number.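

In this assay, chloro in place of hydrogen on the aromatic carbon gave a 1.5-fold higher number from compound 1 to compound 4 (0.17 log units; within the scatter), a step small enough to stay within the ordinary spread of repeated measurements. Set beside the earlier example, the two steps cannot be told apart, so these data give no sign that the size of this change depends on which of the two cores carries it: the same change on two cores in this assay, a 2.2-fold higher number (0.35 log units; beyond the scatter) from compound 2 to compound 3 and a 1.5-fold higher number (0.17 log units; within the scatter) from compound 1 to compound 4, 1.5-fold (0.18 log units) apart, within the scatter of two such steps This does not establish a rule for the series, since it rests on only two pairs of compounds, and the chloro enters a different place in each pair, so the effects of core and place cannot be separated.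

From the compounds shown here alone, it remains open whether the chloro would give a similar step if it entered the core of compound 2 in the same place as in compound 4, ortho to a chloro group. Also open, going by these compounds, is how a different group there, such as an amine, a carboxylic acid or a longer chain, would compare with chloro.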